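The source may report more compounds than this note shows. Statements on the series, on what has been measured and on what is new or still open speak of the compounds shown alone.

Compound 1 `CCCCN(C)S(=O)(=O)NC(=O)Nc1c(C(C)C)cccc1C(C)C` is the weakest point in this small set of three sulfamoylureas sharing one core. In an assay on liver for inhibition of sterol O-acyltransferase 1 (Rattus norvegicus), using microsomes (a lower number here means a stronger inhibitor, a higher number a weaker inhibitor), compound 1 gives 2300 nM, the highest of the three numbers; compound 3 `CC(C)c1cccc(C(C)C)c1NC(=O)NS(=O)(=O)N(Cc1ccccc1)Cc1ccccc1` gives 2200 nM, which lies within the scatter of compound 1, so no order between them can be claimed. Within the data shown here, compound 2 `CCCCCCCCCCCCCCN(C)S(=O)(=O)NC(=O)Nc1c(C(C)C)cccc1C(C)C` gives 330 nM, and the step of a 7.0-fold lower number from compound 1 to compound 2 (0.84 log units; beyond the scatter) is the one clear change in the set.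

Compound 4 `CCCCCCC(C)OS(=O)(=O)NC(=O)Nc1c(C(C)C)cccc1C(C)C` differs from compound 1 by (1-methylheptyl)oxy in place of butyl(methyl)amino on a sulfonyl sulfur. This change exchanges the nitrogen-bound groups for a longer chain attached through oxygen. Among the measured compounds shown here, only the step from compound 1 to compound 2 bears on it, and only in part: it shows that more chain carbons on the sulfonyl side lower the number in this assay, but it says nothing about oxygen replacing nitrogen, for which no pair is measured. Lengthening the chain is therefore expected to help, tempered by the unknown cost of the new attachment, so the estimated step is a 2.9-fold lower number from compound 1 to compound 4 (0.46 log units; beyond the scatter), and compound 4 is expected to give about 800 nM in this assay, within a range of 300 nM to 2500 nM.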

Compound 4, half-maximal inhibitory concentration: 35000 nM
The estimate for compound 4 lay 44-fold (1.64 log units) below the measured number, outside the stated range (above it).
By their numbers in this assay, from the lowest: compound 2; then compounds 3 and 1 (each within the scatter of the next); then compound 4.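

In this assay the exchange of butyl(methyl)amino for (1-methylheptyl)oxy on a sulfonyl sulfur gives a 15-fold higher number from compound 1 to compound 4 (1.18 log units; beyond the scatter) and so shows that the number at this position does not follow chain length alone. The entering group has more heavy atoms, whereas the earlier step of a 7.0-fold lower number from compound 1 to compound 2 (0.84 log units; beyond the scatter) with a longer chain kept the sulfonamide nitrogen and ran the opposite way. No measurement offered here accounts for the rise.

This change replaces the attached atom and the chain together, so the compounds shown do not separate the contribution of the oxygen from that of the branched chain. As far as these compounds go, how a butoxy group, or a (1-methylheptyl)(methyl)amino group, would compare on the same sulfonyl sulfur remains open.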